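Moving the nitro group on the sulfonyl aryl ring

The source may hold more compounds than are shown below. What is called first, only, known or untested is meant among the compounds shown, and "the series" means these compounds.

Measured so far in a functional assay on MCF7 cells (Homo sapiens) for antiproliferative activity; on this read-out lower numbers stand for stronger inhibition and higher numbers for weaker inhibition:
- compound 1 `COC(CN(c1ccccc1CO)S(=O)(=O)c1ccc([N+](=O)[O-])cc1)n1ccc(=O)[nH]c1=O` gives 45800 nM
- compound 2 `COC(CN(c1ccccc1CO)S(=O)(=O)c1ccc([N+](=O)[O-])cc1)n1cc(F)c(=O)[nH]c1=O` gives 55200 nM
- compound 3 `COC(CN(c1ccccc1CO)S(=O)(=O)c1ccccc1[N+](=O)[O-])n1cnc2c(Cl)ncnc21` gives 11300 nM; 3250 nM (2 entries)

Compound 2 has the highest number of the two single values shown. Its nearest neighbour is compound 1, and the step of a 1.2-fold higher number from compound 1 to compound 2 (0.08 log units; within the scatter) is a fluoro in place of hydrogen on an aromatic carbon, a change that stays within the scatter. Compound 3 carries a different core and a 2-nitrophenyl group on its sulfonyl sulfur; its repeated entries the several entries of compound 3 in this assay, 11300 nM; 3250 nM (2 entries) spread widely, which shows how much two measurements of one compound can differ here.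

Compound 4 `COC(CN(c1ccccc1CO)S(=O)(=O)c1ccccc1[N+](=O)[O-])n1cc(F)c(=O)[nH]c1=O` is not yet measured. It differs from compound 2 by 2-nitrophenyl in place of 4-nitrophenyl on a sulfonyl sulfur. For the measured compounds named here, no measured step covers this change: compound 3 is the only compound with a 2-nitrophenyl group, and it differs from compound 2 in more than one place, so its numbers cannot be tied to the sulfonyl aryl group alone. Going by the values given here, the only measured step, a 1.2-fold higher number from compound 1 to compound 2 (0.08 log units; within the scatter), concerns another part of the molecule and lies within the scatter. A step of no clear size beyond the scatter is therefore expected in this assay.

Compound 4 is estimated at 45000 nM, with a range from 15000 nM to 150000 nM. This estimate means an expected step of a 1.2-fold lower number from compound 2 to compound 4 (0.09 log units; within the scatter).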

Compound 4, half-maximal inhibitory concentration: 91000 nM
Estimate against measurement, compound 4: 2.0-fold (0.31 log units) below; the range from low to high includes it.
By their numbers in this assay, from the lowest: compounds 1, 2 and 4 (each within the scatter of the next).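

For the compounds shown here, compound 4 gives the first direct reading of where the nitro group sits on the sulfonyl aryl ring: 2-nitrophenyl in place of 4-nitrophenyl on a sulfonyl sulfur gives a 1.6-fold higher number from compound 2 to compound 4 (0.22 log units; within the scatter). On the core shared by compound 2 and compound 4, the two placings of the nitro group therefore cannot be told apart in this assay. Even this reading has to be taken loosely, since repeated measurements of one compound can lie far apart here: the several entries of compound 3 in this assay, 11300 nM; 3250 nM (2 entries)

The 2-nitrophenyl group of compound 4 also sits on a different core in compound 3, which gives 11300 nM; 3250 nM (2 entries), and the compounds shown include no 4-nitrophenyl partner of compound 3, so it stays open whether moving the nitro group matters on that core. Also open, on these data alone, is whether an amine or a carboxylic acid in place of the nitro group on this ring would produce a step beyond the scatter.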